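This account rests on a few compounds, and the source may have more. Where it says the series, first, only, none or still open, it means among the compounds named here.

Three compounds share one core and differ only in a single group on a six-membered aromatic ring of carbon only. Compound 1 `O=C(N/N=C/c1ccc(-c2ccccc2)cc1)c1cnccn1` carries a phenyl there, compound 2 `O=C(N/N=C/c1ccc(O)cc1)c1cnccn1` a hydroxy, and compound 3 `O=C(N/N=C/c1ccccc1)c1cnccn1` only a hydrogen. In a functional assay on the whole organism (Abdomen, strain Swiss) for inhibition, with Mus musculus as the target, with stated times of 40 min and 25 min, at a dose of 100 umol/kg by the oral route (on this read-out lower numbers stand for less inhibition and higher numbers for more inhibition at the one dose given (going by the name of the read-out)), compound 1 gives 57.3%, compound 2 gives 61.4%, and compound 3 gives 42.4%, the lowest of the three. The step of a number 14.9 percentage points lower from compound 1 to compound 3 (beyond the scatter) and the step of a number 19 percentage points lower from compound 2 to compound 3 (beyond the scatter) both show that taking a group away from this position lowers the read-out by a modest amount, while a number 4.1 percentage points higher from compound 1 to compound 2 (within the scatter) shows that phenyl and hydroxy give numbers within the scatter of each other. Compound 4 `CC(C)c1ccc(/C=N/NC(=O)c2cnccn2)cc1` puts a group back at the same position: isopropyl in place of hydrogen on an aromatic carbon. Both measured steps that bear on this change are modest and point the same way, so a modest rise in this assay is expected. Compound 4 is therefore estimated at 55%, with a range from 42% to 68%, which means an expected step of a number 12.6 percentage points higher from compound 3 to compound 4 (beyond the scatter).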

Compound 4, a percentage reported as inhibition, in the whole organism at one dose (the size of the read-out at that dose, not a potency): 67.6%
Compound 4: middle estimate off by 12.6 percentage points, on the low side; the measured number falls inside the stated range.
By their numbers in this assay, from the lowest: compound 3; then compounds 1, 2 and 4 (each within the scatter of the next, the first and the last beyond it).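

In this assay, isopropyl in place of hydrogen also raises the number (a number 25.2 percentage points higher from compound 3 to compound 4 (beyond the scatter)), so all three groups shown at this position now stand above the plain hydrogen of compound 3, and no compound shown goes against this. Isopropyl has no ring and still reads higher than the phenyl group (a number 10.3 percentage points higher from compound 1 to compound 4 (beyond the scatter)), so a second ring at this position is not needed for the rise, while isopropyl and hydroxy cannot be told apart (a number 6.2 percentage points higher from compound 2 to compound 4 (within the scatter)). Nothing measured here says what lies behind these differences.

As far as these compounds go, what an amine, a carboxylic acid or a longer chain would give at this position stays open. So does whether the number would keep its level with any of these groups in place of isopropyl.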